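From phenyl to cyclohexyl on the sulfonyl sulfur

The source may report more compounds than this note shows. Statements on the series, on what has been measured and on what is new or still open speak of the compounds shown alone.

Of the compounds shown here, three have so far been tested in an ADME assay (liver) for metabolic stability, with Liver microsome (Homo sapiens) as the target, using microsomes, with a stated time of 30 min, tested at 1 uM; on this read-out lower numbers stand for a less stable compound and higher numbers for a more stable compound. Compound 1 `N#C/N=C(\NCc1ccc(S(=O)(=O)c2ccccc2)cc1)Nc1cccnc1` gives 83%, compound 3 `N#C/N=C(\NCc1ccc(S(=O)(=O)N2CC3CCC(C2)O3)cc1)Nc1cccnc1` gives 52%, and compound 2 `N#C/N=C(\NCc1ccc(S(=O)(=O)c2ccccc2)cc1)Nc1ccncc1` gives 96%. Compound 2 therefore stands highest of the three, with both other values lying lower beyond the scatter.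

Compound 4 `N#C/N=C(\NCc1ccc(S(=O)(=O)C2CCCCC2)cc1)Nc1ccncc1` departs from compound 2 in one place: cyclohexyl in place of phenyl on a sulfonyl sulfur. In words, cyclohexyl stands in place of phenyl on a sulfonyl sulfur.

Among the measured compounds shown here, two measured steps bear on this change. The closer one is a number 31 percentage points lower from compound 1 to compound 3 (beyond the scatter), a large step in which a non-aromatic group also replaces phenyl on the sulfonyl sulfur. That entering group is not cyclohexyl, however, and the step was measured with pyridin-3-yl on the amine nitrogen. The other is a number 13 percentage points higher from compound 1 to compound 2 (beyond the scatter), a modest step for pyridin-4-yl in place of pyridin-3-yl, a feature that compound 2 and compound 4 share. For the measured compounds named here, no tested compound carries cyclohexyl, so the size remains uncertain.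

Going by the values given here, the expected change is a number 28 percentage points lower from compound 2 to compound 4 (beyond the scatter), a fall probably somewhat smaller than the one seen for compound 3. Compound 4 is estimated at 68%, within an expected range of 42% to 90%.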

Compound 4, percent of the compound remaining: 56%
Estimate against measurement, compound 4: 12 percentage points above; the range from low to high includes it.
By their numbers in this assay, from the lowest: compounds 3 and 4 (each within the scatter of the next); then compound 1; then compound 2.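

In this assay, cyclohexyl in place of phenyl on the sulfonyl sulfur gives a number 40 percentage points lower from compound 2 to compound 4 (beyond the scatter), although the two groups have the same count of heavy atoms and neither carries a hydrogen-bond donor or acceptor; on these counts, the difference is that the ring is no longer aromatic. The fall appears with a ring of carbon only and with pyridin-4-yl on the amine nitrogen, and it stands alongside a number 31 percentage points lower from compound 1 to compound 3 (beyond the scatter), so in both pairs shown a non-aromatic group in place of phenyl on this sulfur goes with a lower number, and no compound shown goes against this. No measurement at hand accounts for the size of this fall.

The compounds shown leave open how cyclohexyl behaves with pyridin-3-yl on the amine nitrogen, so it cannot yet be said whether the size of the step depends on that part of the molecule. They also leave open whether a pyridine ring, a fluorophenyl group or a small alkyl group such as methyl on the sulfonyl sulfur would stay near compound 2 or fall towards compound 4.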